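The source may report more compounds than this note shows. Statements on the series, on what has been measured and on what is new or still open speak of the compounds shown alone.

The measured compounds and their values in an ADME assay on 2209-23 cells (Homo sapiens) for cytotoxicity, read by WST assay; a lower number here means that less compound is tolerated, a higher number that more compound is tolerated:

compound 1, `O=c1c(C2=CS(=O)(=O)c3cc(O)ccc3N2)c(O)c2cc(F)ccc2n1Cc1ccc(F)cc1` — in this assay compound 1 gives > 50000 nM, which is a limit of the assay and not a number.
compound 2, `CS(=O)(=O)Nc1ccc2c(c1)S(=O)(=O)C=C(c1c(O)c3cc(F)ccc3n(Cc3ccc(F)cc3)c1=O)N2` — in this assay compound 2 gives > 50000 nM, again a limit.
compound 3, `CS(=O)(=O)Nc1ccc2c(c1)S(=O)(=O)C=C(c1c(O)c3ccccc3n(Cc3ccc(F)cc3)c1=O)N2` — in this assay compound 3 gives > 50000 nM, also a limit.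

Compound 3 therefore stands where every shown value stands: at a limit, and no number separates it from compound 1 or compound 2. The two measured steps, a step that the two limits leave unreadable from compound 1 to compound 2 and a step that the two limits leave unreadable from compound 2 to compound 3, cannot be read in size, since both ends of each sit at a limit; the whole of the evidence is the limit of > 50000 nM in this assay, at which 3 of the 3 values shown sit.

The unmeasured compound 4, `CS(=O)(=O)Nc1ccc2c(c1)S(=O)(=O)C=C(c1c(O)c3c(Cl)cccc3n(Cc3ccc(F)cc3)c1=O)N2`, differs from compound 3 by chloro in place of hydrogen on an aromatic carbon. Neither measured step concerns a chloro group, so no step bears directly on this change, and what the shown values offer is only that three compounds of this core, with three different substituents, all sit at the limit. On that basis compound 4 is expected to behave like compound 3, with a step of a number no higher from compound 3 to compound 4 (the limit leaves the size open) that is expected to stay within the scatter. The estimate for compound 4 in this assay is 50000 nM, expected to lie between 20000 nM and 120000 nM, most likely reported again as a limit.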

Compound 4, half-maximal cytotoxic concentration: > 50000 nM
Compound 4: no number, only a limit (the forecaster's own chance of this, stated with the estimate: 80%); the middle value sits exactly at the limit.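

Compound 3 and compound 4 both sit at a limit in this assay, so the step between them, chloro in place of hydrogen on an aromatic carbon, cannot be read in size. The compounds shown leave open at what concentration any of them becomes cytotoxic, and whether any change on the shared core shifts it: the limit of > 50000 nM in this assay, at which 4 of the 4 values shown sit.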